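This account rests on a few compounds, and the source may have more. Where it says the series, first, only, none or still open, it means among the compounds named here.

Within the data shown here, in a functional assay on BT-474 cells (Homo sapiens) for inhibition, read by MTT assay, with a stated time of 5 days (on this read-out lower numbers stand for stronger inhibition and higher numbers for weaker inhibition), compound 1 `Cc1cc(Nc2nc(NCc3ccc(F)cc3F)nc3c2cnn3C2CCOCC2)n[nH]1` gives 2350 nM, the lower of the only two numbers available so far. The other number comes from compound 2 `Cc1cc(Nc2nc(NCc3ccc(F)cc3F)nc3c2cnn3C(C)C)n[nH]1`, which gives 17300 nM. Compound 3 `CCc1cc(Nc2nc(NCc3ccc(F)cc3F)nc3c2cnn3C2CCOCC2)n[nH]1` keeps the core of compound 1 and differs from it in one place: methyl in place of hydrogen on a saturated chain carbon bound to an aromatic carbon. Methyl takes the place of hydrogen on a saturated chain carbon bound to an aromatic carbon, which turns 5-methyl-1H-pyrazol-3-yl into 5-ethyl-1H-pyrazol-3-yl. Among the measured compounds shown here, the only measured step is a 7.4-fold higher number from compound 1 to compound 2 (0.87 log units; beyond the scatter). It puts isopropyl in place of oxan-4-yl on an aromatic nitrogen, which is not the place that changes in compound 3. For the measured compounds named here, that step shows that a change elsewhere in the structure can move the number, but no measured pair tests methyl against ethyl. The step therefore gives only indirect guidance, and a small shift in either direction, probably within the scatter, is expected in this assay. The expected change is a 1.1-fold lower number from compound 1 to compound 3 (0.03 log units; within the scatter). For compound 3 the estimated value is 2200 nM, with an expected range from 850 nM to 6000 nM.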

Compound 3, half-maximal inhibitory concentration: 3060 nM
The estimate for compound 3 lay 1.4-fold (0.14 log units) below the measured number; the measured number falls inside the stated range.
By their numbers in this assay, from the lowest: compounds 1 and 3 (each within the scatter of the next); then compound 2.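

In this assay, extending 5-methyl-1H-pyrazol-3-yl to 5-ethyl-1H-pyrazol-3-yl gives a 1.3-fold higher number from compound 1 to compound 3 (0.11 log units; within the scatter), so adding a methyl on this saturated chain carbon bound to an aromatic carbon produces no change that can be told apart from ordinary assay scatter. Among these compounds, this is the first measured test at this place, since the earlier step, a 7.4-fold higher number from compound 1 to compound 2 (0.87 log units; beyond the scatter), involved a change on an aromatic nitrogen and said nothing about the methyl of the pyrazole. Nothing measured here explains why the extra methyl leaves the number within the scatter.

Going by these compounds, a single added carbon is a small probe, so it remains unknown whether a longer chain such as propyl, a cyclopropyl ring, or a chain ending in an amine or a carboxylic acid would also leave the number within the scatter or would move it clearly in either direction. The compounds shown also leave open whether ethyl would give a similar result when isopropyl replaces oxan-4-yl on the aromatic nitrogen.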